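A few compounds are considered here, and "the series" means these few. Any claim that something is new, unique, unknown or untested is made for them only; others in the source may bear on it.

The account is set in a functional assay for agonist activity at G protein-coupled receptor 88 (Homo sapiens), read by HTRF and cAMP accumulation; on this read-out lower numbers stand for an effect already at smaller amounts and higher numbers for an effect only at larger amounts of compound. Compound 1 `O=C([C@@H]1C[C@H]1c1ccccc1)N(CCNCC1CCCCC1)c1ccc(-c2ccccc2)cc1` gives 6.6 nM in this assay, and compound 2 `O=C([C@@H]1C[C@H]1c1ccccc1)N(CCNCC1CCCC1)c1ccc(-c2ccccc2)cc1` gives 2.5 nM. Among the compounds with values here, the single step between them, a 2.6-fold lower number from compound 1 to compound 2 (0.42 log units; beyond the scatter), concerns the amine chain and leaves the aryl group on the three-membered ring untouched. Compound 3 `CC[C@H](C)[C@H](N)CN(C(=O)[C@@H]1C[C@H]1c1ccc(OC)cc1)c1ccc(-c2ccccc2)cc1` carries a branched chain with a free amine and a 4-methoxyphenyl on that ring. For compound 3 this assay returns only a limit, > 25000 nM, and no number is known for it. Compound 3 thus stands at the limit of > 25000 nM in this assay, at which 1 of the 3 values shown sits, apart from the two compounds with numbers.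

Compound 4 `CC[C@H](C)[C@H](N)CN(C(=O)[C@@H]1C[C@H]1c1cc(F)ccc1F)c1ccc(-c2ccccc2)cc1` differs from compound 3 in one place: 2,5-difluorophenyl in place of 4-methoxyphenyl on a saturated ring carbon. No measured step bears on the aryl group of the three-membered ring; the one step shown runs elsewhere in the molecule and was modest. The measured pairs therefore give no size or direction for the step from compound 3 to compound 4, and because compound 3 sits at the limit of > 25000 nM in this assay, at which 1 of the 3 values shown sits, the step is known only as far as compound 4 itself returns a number.

Compound 4 is expected to stay weak, with an estimated step of an at least 2.5-fold lower number from compound 3 to compound 4 (0.39 log units; beyond the scatter). The estimate for compound 4 in this assay is 10000 nM, within a range from 500 nM to 25000 nM, with a real chance that only a limit is reported again.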

Compound 4, half-maximal effective concentration: 770 nM
For compound 4 the middle estimate is 13-fold (1.11 log units) above the measured one; the measured number falls inside the stated range.
By their numbers in this assay, from the lowest: compound 2; then compound 1; then compound 4. At a limit, above all of these: compound 3.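

Within the data shown here, the aryl group on the saturated ring carbon of the three-membered ring proves to be a sensitive place in this assay: with the branched free-amine chain held fixed, 2,5-difluorophenyl in place of 4-methoxyphenyl gives a large change (an at least 32-fold lower number from compound 3 to compound 4 (1.51 log units; beyond the scatter)), whereas the earlier compounds showed only a modest step on the amine chain (a 2.6-fold lower number from compound 1 to compound 2 (0.42 log units; beyond the scatter)). The branched chain with its free amine therefore does not by itself rule out a measurable effect, since compound 4 gives 770 nM while carrying that chain. The true size of the step remains unknown, and the printed figure is only a lower bound because compound 3 has no number, just a limit: the limit of > 25000 nM in this assay, at which 1 of the 4 values shown sits.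

The compounds shown do not separate the effect of losing the 4-methoxyphenyl group from that of adding the two fluorines, a question that an unsubstituted phenyl, a single fluorine or a chlorophenyl on this chain could address. As far as these compounds go, it also remains open whether the same exchange would carry over to compounds with the cyclopentyl or cyclohexyl amine chains, whose aryl group on the three-membered ring is plain phenyl.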